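Adding a third methoxy to the chalcone aryl ring

The source may hold more compounds than are shown below. What is called first, only, known or untested is meant among the compounds shown, and "the series" means these compounds.

Compound 1 `COc1ccc(C(=O)/C=C/c2cc(-c3cc(OC)c(OC)c(OC)c3)n[nH]2)cc1OC` stands lowest of the two numbers in a functional assay on RPMI-8226 cells (Homo sapiens) for cytotoxicity, read by sulforhodamine B assay, with a stated time of 48 h, tested at 10 uM (on this read-out higher numbers stand for a weaker effect at the one concentration tested and lower numbers for a stronger effect), where compound 1 gives -50%. Compound 2 `COc1ccc(C(=O)/C=C/c2cc(-c3cc(OC)c(OC)c(OC)c3)n[nH]2)cc1` gives -41% in this assay, and the step of a number 9 percentage points higher from compound 1 to compound 2 (within the scatter) is within the scatter. Compound 3 `COc1cc(C(=O)/C=C/c2cc(-c3cc(OC)c(OC)c(OC)c3)n[nH]2)cc(OC)c1OC` differs from compound 1 by methoxy in place of hydrogen on an aromatic carbon. Among the compounds with values here, the only measured step bearing on this change is a number 9 percentage points higher from compound 1 to compound 2 (within the scatter), which concerns a methoxy at another aromatic carbon and stayed within the scatter, so no step beyond the scatter is expected. Compound 3 is estimated at -52% in this assay, between -75% and -25%, an expected step of a number 2 percentage points lower from compound 1 to compound 3 (within the scatter).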

Compound 3, a percentage reported as activity, at one concentration (the size of the read-out at that concentration, not a potency): -38%
Beside the measured number, compound 3's estimate is 14 percentage points below it, and the stated range covers the measured number.
By their numbers in this assay, from the lowest: compounds 1, 2 and 3 (each within the scatter of the next, the first and the last beyond it).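

Adding the methoxy ortho to a methoxy group gives a number 12 percentage points higher from compound 1 to compound 3 (beyond the scatter) in this assay, a modest weakening of the effect at the one concentration tested. This is the first step on this ring that lies beyond the scatter, since a number 9 percentage points higher from compound 1 to compound 2 (within the scatter) does not, so the ring is shown to tolerate some changes less well than others. The compounds shown leave open whether a hydroxyl or an amine on this same aromatic carbon would give a number closer to that of compound 1. Nothing available accounts for the step.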